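The source may hold more compounds than are shown below. What is called first, only, known or untested is meant among the compounds shown, and "the series" means these compounds.

In an assay on isolated protein for inhibition of Amine oxidase [flavin-containing] B (Homo sapiens) (on this read-out lower numbers stand for stronger inhibition and higher numbers for weaker inhibition), two compounds have been measured so far. Going by the values given here, compound 1 `C#CCNC1CCc2c(SCc3ccc(C(F)(F)F)cc3)cccc21` gives 9680 nM, while compound 2 `C#CCNC1CCc2c(SCc3ccc(C)cc3)cccc21` gives 1560 nM, so compound 2 holds the lowest of the two numbers, with compound 1 as its only neighbour. The single step shown, a 6.2-fold lower number from compound 1 to compound 2 (0.79 log units; beyond the scatter), came from exchanging the group on the outer aromatic ring and moved the read-out by a modest but real amount. Compound 3 `C#CCNC1CCc2c(SCc3ccc(OC)cc3)cccc21` has not yet been measured; it differs from compound 2 by methoxy in place of methyl on an aromatic carbon. Among the compounds with values here, no measured pair tells how methoxy compares with methyl at this place, so the only guide is that one earlier change at the same position gave a modest step. The expectation is therefore that compound 3 stays close to compound 2, with the step of a 1.0-fold lower number from compound 2 to compound 3 (0.02 log units; within the scatter) expected to fall within the scatter. Compound 3 is estimated at 1500 nM, within a range from 500 nM to 5000 nM.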

Compound 3, half-maximal inhibitory concentration: 1900 nM
Beside the measured number, compound 3's estimate is 1.3-fold (0.10 log units) below it, within the range that was stated.
By their numbers in this assay, from the lowest: compounds 2 and 3 (each within the scatter of the next); then compound 1.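

In this assay the exchange of methyl for methoxy, on an aromatic carbon para to a large group, stays within the scatter (a 1.2-fold higher number from compound 2 to compound 3 (0.09 log units; within the scatter)), even though methoxy brings in an oxygen and a hydrogen-bond acceptor. Trifluoromethyl to methoxy is a modest step beyond the scatter (a 5.1-fold lower number from compound 1 to compound 3 (0.71 log units; beyond the scatter)), so among these three compounds only compound 1, with trifluoromethyl, stands apart from the other two. No measurement at hand explains why these groups compare as they do.

On these data alone, it remains open whether a longer chain such as ethoxy would also stay close to methyl and methoxy at this place. An amine or a carboxylic acid there could show whether this tolerance extends to quite different groups.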